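Replacing the benzyl group on the ring amine

This account rests on a few compounds, and the source may have more. Where it says the series, first, only, none or still open, it means among the compounds named here.

Measured compounds:
compound 1, `NC(=O)c1c(NC(=O)c2ccccc2Cl)sc2c1CCN(Cc1ccc(Cl)cc1)C2`: 22500 nM
compound 2, `Cc1ccc(C(=O)Nc2sc3c(c2C(N)=O)CCN(Cc2ccc(Cl)cc2Cl)C3)cc1`: 19900 nM
compound 3, `NC(=O)c1c(NC(=O)c2cccc([N+](=O)[O-])c2)sc2c1CCN(Cc1ccc(Cl)cc1Cl)C2`: 19800 nM

In a functional assay on HL-60 cells (Homo sapiens) for antiproliferative activity, with a stated time of 24 h (on this read-out higher numbers stand for weaker inhibition and lower numbers for stronger inhibition), compound 1 has the largest of the three numbers, yet compound 2 and compound 3 both sit within the usual scatter of it, so the three cannot be told apart on these data. Among the measured compounds shown here, the only measured step, a 1.0-fold lower number from compound 2 to compound 3 (0.00 log units; within the scatter), swaps the group on the carbonyl carbon and leaves the number unchanged; it does not touch the amine nitrogen in the ring, and so bears on the step to compound 4 only by showing that one change elsewhere in the shared core made no difference. Compound 4, `NC(=O)c1c(NC(=O)c2ccccc2Cl)sc2c1CCN(C(=S)Nc1cccnc1)C2`, differs from compound 1 at that ring amine: a group of 9 heavy atoms (6 carbon, 2 nitrogen, 1 sulfur; one six-membered aromatic ring with 1 hetero atom) in place of a group of 8 heavy atoms (7 carbon, 1 chlorine; one six-membered aromatic ring of carbon only), on an amine nitrogen in a ring. For the measured compounds named here, no measured pair covers this position, so the expectation rests on compound 1 alone, and the range is set wide. Compound 4 is therefore estimated at 20000 nM, between 5000 nM and 80000 nM, which is expected to correspond to a 1.1-fold lower number from compound 1 to compound 4 (0.05 log units; within the scatter).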

Compound 4, half-maximal inhibitory concentration: 33900 nM
Compound 4: middle estimate off by 1.7-fold (0.23 log units), on the low side, and the stated range covers the measured number.
By their numbers in this assay, from the lowest: compounds 3, 2, 1 and 4 (each within the scatter of the next).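

In this assay, putting the group with the pyridine-type ring and thiocarbonyl in place of 4-chlorobenzyl on the amine nitrogen in the ring gives a 1.5-fold higher number from compound 1 to compound 4 (0.18 log units; within the scatter), the first step read at this position. The entering group brings 1 hydrogen-bond donor, 2 hydrogen-bond acceptors and a ring with 1 hetero atom where the leaving group has no donor, no acceptor and a ring of carbon only, and still the step stays within the scatter, so this exchange at the ring amine cannot be told apart from no change. No measurement available here accounts for this result.

The compounds shown leave open whether a small group on this nitrogen, such as methyl or acetyl, or a carboxylic acid on a longer chain, would give a step beyond the scatter. They also leave open whether the same exchange would read alike with a group other than 2-chlorophenyl on the carbonyl carbon.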